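A few compounds are considered here, and "the series" means these few. Any claim that something is new, unique, unknown or untested is made for them only; others in the source may bear on it.

Compound 1, `CC(=O)OC(C)n1cnc2c(S)nc(N)nc21`, gives in a functional assay on HT-29 cells (Homo sapiens) for inhibition (a higher number here means a weaker inhibitor, a lower number a stronger inhibitor), only the limit > 500000 nM. Compound 2, `CC(=O)OC(C)n1cnc2c(S)nc(F)nc21`, likewise gives in this assay only the limit > 500000 nM.

Compound 2 thus stands at a limit in this assay, and the step that the two limits leave unreadable from compound 1 to compound 2 cannot be read since both of its values sit at the limit of > 500000 nM in this assay, at which 2 of the 2 values shown sit. Compound 3, `CC(O)n1cnc2c(S)nc(F)nc21`, differs from compound 2 by hydrogen in place of acetyl on an oxygen on a saturated carbon. No measured step bears on this change, and the single step shown is itself unreadable. The step that this estimate means, a number no higher from compound 2 to compound 3 (the limit leaves the size open), is expected to be no shift beyond the scatter. Compound 3 is estimated at 500000 nM, with a range from 100000 nM to 2000000 nM, and most probably again only as a limit.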

Compound 3, half-maximal inhibitory concentration: > 500000 nM
Compound 3: only a limit was reported; the forecaster's own chance of this, stated with the estimate: 85%; the middle value sits exactly at the limit.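

In this assay compound 3 gives only the limit > 500000 nM, so its step from compound 2 cannot be read. Compounds 1, 2 and 3 leave open whether either change affects inhibition at all.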